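The source may report more compounds than this note shows. Statements on the series, on what has been measured and on what is new or still open speak of the compounds shown alone.

Compound 1 `CCOC(=O)c1c(-c2cccc(Cl)c2)[nH]c2cc(OC)ccc2c1=O`: > 21500 nM, a limit
Compound 2 `CCOC(=O)c1c(-c2cccc(OC)c2)[nH]c2cc(OC(C)C)ccc2c1=O`: > 21500 nM, a limit
Compound 3 `CCOC(=O)c1c(-c2cccc(OC)c2)[nH]c2cc(C(F)(F)F)ccc2c1=O`: > 21500 nM, a limit

Of the compounds shown here, three have been tested in an ADME assay on Raji cells (Homo sapiens) for cytotoxicity, read by luminescence, with a stated time of 72 h (a higher number here means that more compound is needed for the effect, a lower number that less compound is needed), and none of them has given a number. The record for the series is the limit of > 21500 nM in this assay, at which 3 of the 3 values shown sit. In this assay compound 3 gives > 21500 nM, which is a limit of the assay and not a number.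

Compound 4 `CCOC(=O)c1c(-c2cccc(Cl)c2)[nH]c2cc(C(F)(F)F)ccc2c1=O` keeps the core and the trifluoromethyl group of compound 3. It differs in one place, where the 3-methoxyphenyl group becomes 3-chlorophenyl, with chloro in place of methoxy on an aromatic carbon, meta to a large group (chloro in place of methoxy on an aromatic carbon).

For the measured compounds named here, the only measured step is a step that the two limits leave unreadable from compound 2 to compound 3. It involves a different change, trifluoromethyl in place of isopropoxy, and it offers no size to carry over. Compound 1 already carries the 3-chlorophenyl group. Compound 1 gives > 21500 nM, again a limit.

Nothing measured therefore points to a step in either direction, and no change beyond the scatter is expected. The expected outcome is a number no higher from compound 3 to compound 4 (the limit leaves the size open), most likely reported only as a limit. For compound 4 the estimated value is 21500 nM, with an expected range of 9000 nM to 30000 nM.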

Compound 4, half-maximal effective concentration: > 21500 nM
Compound 4: a limit, no number; the forecaster's own chance of this, stated with the estimate: 80%; the middle value lies on the limit itself.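

In this assay compound 4 gives > 21500 nM as a limit of the assay and not a number. With limits on both sides, the steps to compound 4 from compound 3 and from compound 1 cannot be read. The compounds shown leave open whether any of these changes moves the value at all, since all that they offer is this: the limit of > 21500 nM in this assay, at which 4 of the 4 values shown sit.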